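Urea aryl exchange from compound 2 to compound 3

The compounds below may be only part of what the source reports. "The series", "measured", "known", "first", "only" and "open" are said of these compounds alone.

The series rests on two measured compounds. Compound 1 `O=C(Nc1cccc(-n2cc(-c3ccncc3)c(-c3ccc(Cl)c(O)c3)n2)c1)Nc1cccc(C(F)(F)F)c1` was tested in a functional assay on MDA-MB-435 cells (Homo sapiens) for inhibition, read by sulforhodamine B assay, with a stated time of 48 h (on this read-out lower numbers stand for higher toxicity in this test and higher numbers for lower toxicity in this test), and gave only a limit of the assay, > 32500 nM. Compound 2 `COc1cc(-c2nn(-c3cccc(NC(=O)Nc4ccc(Cl)c(Cl)c4)c3)cc2-c2ccncc2)ccc1Cl` also reaches only a limit of the assay in this assay, > 50000 nM. Compound 2 therefore stands at the limit of > 50000 nM in this assay, at which 1 of the 2 values shown sits, and the other measured value is likewise a limit, (the limit of > 32500 nM in this assay, at which 1 of the 2 values shown sits), so no number for compound 2 can be placed in order against compound 1; both simply sit beyond the range in which the assay reports a figure.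

Compound 3 `COc1cc(-c2nn(-c3cccc(NC(=O)Nc4cccc(C(F)(F)F)c4)c3)cc2-c2ccncc2)ccc1Cl` is compound 2 with one change: 3-(trifluoromethyl)phenyl in place of 3,4-dichlorophenyl on an amide-type nitrogen. No measured step of this kind is shown, so no size can be taken from the data. Since compound 1 carries the same 3-(trifluoromethyl)phenyl urea and gives only > 32500 nM, and compound 2 gives only > 50000 nM, the author expects the step of a number no higher from compound 2 to compound 3 (the limit leaves the size open) to stay within the scatter. Compound 3 is estimated at 50000 nM, between 20000 nM and 120000 nM, most likely reported again as a limit.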

Compound 3, concentration lethal to 50% of the cells: 8070 nM
Estimate against measurement, compound 3: 6.2-fold (0.79 log units) above, and the stated range ends above it.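

Compound 3 is the only compound shown that gives a figure rather than a limit in this assay, so both of its neighbours can now be stepped to it, and both places turn out to affect the read-out: 3-(trifluoromethyl)phenyl in place of 3,4-dichlorophenyl on an amide-type nitrogen gives an at least 6.1-fold lower number from compound 2 to compound 3 (0.79 log units; beyond the scatter), and methyl in place of hydrogen on an oxygen on an aromatic ring gives an at least 4.0-fold lower number from compound 1 to compound 3 (0.60 log units; beyond the scatter). From the compounds shown here alone, the true size of the first step stays open on one side, as compound 2 has only a limit of the assay: the limit of > 50000 nM in this assay, at which 1 of the 3 values shown sits. The second step is open in the same way, as compound 1 also has only a limit of the assay: the limit of > 32500 nM in this assay, at which 1 of the 3 values shown sits.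

The compounds shown leave open how far each step really reaches, and whether either change would have the same effect with the other place altered, as no pair here has two figures. Going by these compounds, it also remains open how the read-out would respond to a carboxylic acid or an amine on the urea aryl ring, or to a longer chain in place of the methyl on the oxygen.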